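The source may report more compounds than this note shows. Statements on the series, on what has been measured and on what is new or still open speak of the compounds shown alone.

Compound 1 `CC(C)(C)c1cn(C[C@H](O)[C@H]2OC(=O)C(OCc3ccccc3)=C2OCc2ccccc2)nn1` gives 18300 nM in a functional assay on HeLa cells (Homo sapiens) for antiproliferative activity, read by MTT assay, with a stated time of 72 h; a lower number here means a stronger inhibitor, a higher number a weaker inhibitor.
Compound 2 `Cc1ccc(-c2cn(C[C@H](O)[C@H]3OC(=O)C(OCc4ccccc4)=C3OCc3ccccc3)nn2)cc1` gives 25500 nM in this assay.

Compound 2 carries the highest of the two numbers measured, but its nearest neighbour is compound 1, and the step of a 1.4-fold higher number from compound 1 to compound 2 (0.14 log units; within the scatter) lies within the scatter, so the two compounds are not truly separated. Compound 3 `O=C1O[C@H]([C@@H](O)Cn2cc(-c3cc(F)cc(F)c3)nn2)C(OCc2ccccc2)=C1OCc1ccccc1` differs from compound 2 by 3,5-difluorophenyl in place of 4-methylphenyl on an aromatic carbon. Among the measured compounds shown here, only one measured step exists, a 1.4-fold higher number from compound 1 to compound 2 (0.14 log units; within the scatter), and it bears on the present change only loosely: there a tert-butyl gave way to an aryl group, whereas here one aryl group replaces another. That step stayed within the scatter, and nothing else is known about this position. No change beyond the scatter is therefore expected, and the estimated step is a 1.2-fold lower number from compound 2 to compound 3 (0.06 log units; within the scatter). Compound 3 is expected to give about 22000 nM in this assay, within a range from 8000 nM to 60000 nM.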

Compound 3, half-maximal inhibitory concentration: 40800 nM
The estimate for compound 3 lay 1.9-fold (0.27 log units) below the measured number; the measured number falls inside the stated range.
By their numbers in this assay, from the lowest: compounds 1, 2 and 3 (each within the scatter of the next, the first and the last beyond it).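

In this assay, exchanging one aryl group for another at this aromatic carbon gives a 1.6-fold higher number from compound 2 to compound 3 (0.20 log units; within the scatter) so the 3,5-difluorophenyl and 4-methylphenyl groups cannot be told apart here, even with two fluorines on the ring. Among the compounds shown here, the comparison with the tert-butyl group does clear the scatter, with a 2.2-fold higher number from compound 1 to compound 3 (0.35 log units; beyond the scatter) and this gives the first sign that the group at this position can affect the number, though only modestly. It is no general rule for aryl groups, since compound 2 goes against it by staying within the scatter of compound 1, and no measurement on hand accounts for the gap.

From the compounds shown here alone, it remains open whether an amine or a carboxylic acid at this position would shift the number further. A longer alkyl chain in place of the tert-butyl group is equally untested by the compounds shown here.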